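The source may hold more compounds than are shown below. What is called first, only, known or untested is meant among the compounds shown, and "the series" means these compounds.

Of the compounds shown here, three have so far been measured in an assay on membranes from Jurkat cells for displacement of a labelled ligand from Sigma non-opioid intracellular receptor 1 (Homo sapiens), read by scintillation counting, with a stated time of 2 h; a lower number here means a stronger inhibitor, a higher number a weaker inhibitor. Compound 1, `Cn1nc(CN2CCCC2)nc1-c1ccc2ccsc2c1`, gives 64 nM. Compound 2, `CC(C)(C)c1ccc(-c2nc(CN3CCCC3)nn2C2CC2)cc1`, gives 14 nM. Compound 3, `Cn1nc(CN2CCCC2)nc1-c1cccc(C(C)(C)C)c1`, gives 29 nM. Among these three numbers compound 3 stands second highest: its nearest neighbour is compound 2, which sits lower by a margin beyond the usual scatter, and its furthest is compound 1, which sits higher, again beyond the scatter.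

Compound 4, `Cn1nc(CN2CCCC2)nc1-c1cccc(C2(C(F)(F)F)CC2)c1`, has not yet been measured. It differs from compound 3 in one place: 1-(trifluoromethyl)cyclopropyl in place of tert-butyl on an aromatic carbon. Among the measured compounds shown here, no measured pair shows this same change, so the data give no direct guide to the size of the step. The group that enters is larger than the one that leaves, and both are without donors, acceptors or charge. Since nothing measured points either way, the step is expected to be small, a 1.2-fold higher number from compound 3 to compound 4 (0.08 log units; within the scatter), within or close to the scatter in this assay. Compound 4 is therefore estimated to give 35 nM, with a plausible range from 12 nM to 100 nM.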

Compound 4, inhibition constant: 32 nM
The estimate for compound 4 lay 1.1-fold (0.04 log units) above the measured number; the measured number falls inside the stated range.
By their numbers in this assay, from the lowest: compound 2; then compounds 3, 4 and 1 (each within the scatter of the next, the first and the last beyond it).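

In this assay, among the compounds shown here, replacing tert-butyl with 1-(trifluoromethyl)cyclopropyl gives a 1.1-fold higher number from compound 3 to compound 4 (0.04 log units; within the scatter), the first step measured between compounds that differ in one place. On this aromatic carbon, meta to a large group, the entering group brings more heavy atoms, a three-membered ring and fluorine, yet compound 3 and compound 4 cannot be told apart. Nothing measured here bears on why the two groups read alike.

As far as these compounds go, it remains open how a carboxylic acid or a primary amine on the same aromatic carbon would read in this assay, since both groups compared here are without donors, acceptors or charge. From the compounds shown here alone, it also remains open whether the same exchange would read alike on compound 2, which carries a tert-butyl group as well.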